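Compound 1 and the step to an aminophenyl group

A few compounds are considered here, and "the series" means these few. Any claim that something is new, unique, unknown or untested is made for them only; others in the source may bear on it.

In an ADME assay on microsomes from liver (Homo sapiens) for metabolic stability, read by LC-MS, using NADPH, with a stated time of 30 min, tested at 0.1 uM (a higher number here means that more of the compound is left, a lower number that less of the compound is left), the measured compounds stand as follows:
- compound 1 `CS(=O)(=O)Nc1ccc2nccc(-c3ccncc3)c2n1` gives 96% remaining
- compound 2 `O=S(=O)(NCCN1CCCC1)c1cccc(-c2ccc3nccc(-c4ccnc(C(F)(F)F)c4)c3n2)c1` gives 14% remaining
- compound 3 `NS(=O)(=O)c1ccc(-c2ccc3nccc(-c4ccncc4)c3n2)cc1` gives 76% remaining

Compound 1 holds the highest of the three numbers, and both other compounds lie lower, beyond the scatter. Compound 4 `Nc1cccc(-c2ccc3nccc(-c4ccncc4)c3n2)c1` carries 3-aminophenyl in place of methanesulfonamido on an aromatic carbon. Going by the values given here, no two measured compounds differ in one place only, so the expectation rests on a looser comparison. Compound 3 also has a six-membered aromatic ring of carbon only at that carbon and gives 76% in this assay, while compound 2, likewise, gives 14% there. A fall beyond the scatter is therefore expected, with the estimated a number 36 percentage points lower from compound 1 to compound 4 (beyond the scatter) as its size. Compound 4 is expected at 60%, within an estimated range from 30% to 85%.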

Compound 4, percent of the compound remaining: 78%
The estimate for compound 4 lay 18 percentage points below the measured number; the measured number falls inside the stated range.
By their numbers in this assay, from the lowest: compound 2; then compounds 3 and 4 (each within the scatter of the next); then compound 1.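

Going by these compounds alone, with this pair, a change at this aromatic carbon can be read on its own for the first time: in this assay, 3-aminophenyl in place of methanesulfonamido gives a number 18 percentage points lower from compound 1 to compound 4 (beyond the scatter), a modest step. The position therefore accepts a six-membered aromatic ring of carbon only, at a measurable but limited cost in the percent of compound remaining. Nothing shown here gives a measured reason for this step. As far as these compounds go, whether the step belongs to the ring or to its amino group stays open, as does how a plain phenyl or a carboxylic acid at this carbon would stand in this assay.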